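Swapping one ring on a rapidly cleared compound

A few compounds are considered here, and "the series" means these few. Any claim that something is new, unique, unknown or untested is made for them only; others in the source may bear on it.

Among the measured compounds shown here, in an in vitro ADME assay on microsomes from liver (Rattus norvegicus) for metabolic stability (on this read-out lower numbers stand for slow clearance and higher numbers for fast clearance), compound 1 `CC(C)NC(=O)[C@H]1CC[C@@H](n2/c(=N/C(=O)c3ccc(F)cc3)[nH]c3ccc(CN4CCC[C@H]4C(C)(C)O)cc32)CC1` gives 455 mL.min-1.g-1 as the only exact number so far. Compound 2 `CC(C)NC(=O)[C@H]1CC[C@@H](n2/c(=N/C(=O)c3cccnc3)[nH]c3ccc(CN4CCC(C(C)(C)O)CC4)cc32)CC1` gives < 14 mL.min-1.g-1 which is a limit of the assay. Compound 3 `CC(C)NC(=O)[C@H]1CC[C@@H](n2/c(=N/C(=O)c3ccc(F)cc3)[nH]c3ccc(CN4CCNC(=O)C4)cc32)CC1` departs from compound 1 through 3-oxopiperazin-1-yl in place of 2-(1-hydroxy-1-methylethyl)pyrrolidin-1-yl on a saturated chain carbon bound to an aromatic carbon on a saturated chain carbon bound to an aromatic carbon. Since compound 1 stands at 455 mL.min-1.g-1 there is ample room for a fall. The expected change is a 10-fold lower number from compound 1 to compound 3 (1.00 log units; beyond the scatter) in this assay and would lie beyond the scatter. Compound 3 is expected at 45 mL.min-1.g-1 within an estimated range of 14 mL.min-1.g-1 to 150 mL.min-1.g-1 in this measurement.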

Compound 3, intrinsic clearance in microsomes: 45 mL.min-1.g-1
Beside the measured number, compound 3's estimate shows no gap at the digits printed, within the range that was stated.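

Among the compounds shown here, compound 1 and compound 2 differ in more than one place, so they gave no single step at the saturated chain carbon bound to an aromatic carbon. With the rest of the structure held fixed, 3-oxopiperazin-1-yl in place of 2-(1-hydroxy-1-methylethyl)pyrrolidin-1-yl gives a 10-fold lower number from compound 1 to compound 3 (1.00 log units; beyond the scatter) in this assay, so this read-out responds to the group at this place. Compound 2 gives a limit of the assay and not a number: the limit of < 14 mL.min-1.g-1 in this assay, at which 1 of the 3 values shown sits.

As far as these compounds go, whether the step depends on the ring carbonyl or on the loss of the 1-hydroxy-1-methylethyl group stays open. A plain piperazine or morpholine at this place would help to separate the two.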